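From trifluoromethoxy to trifluoromethyl on a shared core

The source may report more compounds than this note shows. Statements on the series, on what has been measured and on what is new or still open speak of the compounds shown alone.

Values so far in a functional assay on HepG2 cells (Homo sapiens) for inhibition, read by sulforhodamine B assay, with a stated time of 74 h (a lower number here means a stronger inhibitor, a higher number a weaker inhibitor), are these
- compound 1 `Cc1ccccc1S(=O)(=O)N1C(=O)COC12C=CC(=O)C=C2` gives 750 nM
- compound 2 `O=C1C=CC2(C=C1)OCC(=O)N2S(=O)(=O)c1ccccc1OC(F)(F)F` gives > 10000 nM (a limit, not a number)

Compound 2 sits at > 10000 nM in this assay and this is a limit of the assay. Compound 3 `O=C1C=CC2(C=C1)OCC(=O)N2S(=O)(=O)c1ccccc1C(F)(F)F` differs from it by this change trifluoromethyl in place of trifluoromethoxy on an aromatic carbon and so has trifluoromethyl in place of trifluoromethoxy on an aromatic carbon. Going by the values given here, one measured step bears on this place, namely an at least 13-fold higher number from compound 1 to compound 2 (1.12 log units; beyond the scatter) when trifluoromethoxy replaced methyl. Trifluoromethyl is a different group from both, so compound 3 may fall between the two, because compound 1 with methyl gives 750 nM in this assay as a clear number. The expected move is an at least 3.3-fold lower number from compound 2 to compound 3 (0.52 log units; beyond the scatter) toward a lower number and stronger inhibition. For compound 3 the estimated value is 3000 nM with an expected range from 600 nM to 12000 nM in that assay's terms.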

Compound 3, half-maximal inhibitory concentration: 590 nM
Estimate against measurement, compound 3: 5.1-fold (0.71 log units) above, outside the stated range (below it).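

In this assay, the one oxygen that sets trifluoromethoxy apart from trifluoromethyl matters greatly at this place on the aromatic ring, with an at least 16-fold lower number from compound 2 to compound 3 (1.22 log units; beyond the scatter) for this change. The value of compound 2 is a limit of the assay, not a number: the limit of > 10000 nM in this assay, at which 1 of the 3 values shown sits. The fluorines alone do not set compound 2 apart, since trifluoromethyl and methyl cannot be told apart here, with a 1.3-fold lower number from compound 1 to compound 3 (0.10 log units; within the scatter) for that swap.

As far as these compounds go, what a methoxy group or an amine would give at this place stays open. So does whether the oxygen by itself weakens inhibition.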